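Bromo for cyano on the phenyl ring

This account rests on a few compounds, and the source may have more. Where it says the series, first, only, none or still open, it means among the compounds named here.

Among the compounds with values here, an aromatic nitrogen of the shared core carries a substituted phenyl ring, and only this ring is varied. Compound 1 `CC1(C)[C@H]2CC[C@]1(C)N(Cc1cn(-c3cccc(Cl)c3)nn1)C(=O)C2` bears a 3-chlorophenyl there; in a functional assay on PANC-1 cells (Homo sapiens) for inhibition, read by MTT assay, with a stated time of 24 h (a lower number here means a stronger inhibitor, a higher number a weaker inhibitor), compound 1 gives 260 nM. Compound 2 `CC1(C)[C@H]2CC[C@]1(C)N(Cc1cn(-c3ccccc3C#N)nn1)C(=O)C2` bears a 2-cyanophenyl instead, and in this assay compound 2 gives 240 nM. Within the data shown here, the single measured step, a 1.1-fold lower number from compound 1 to compound 2 (0.03 log units; within the scatter), is within the scatter, so compound 2 stands level with compound 1 and the two numbers cannot be told apart.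

Compound 3 `CC1(C)[C@H]2CC[C@]1(C)N(Cc1cn(-c3ccccc3Br)nn1)C(=O)C2` differs from compound 2 by bromo in place of cyano on an aromatic carbon. Among the measured compounds shown here, no measured step exchanges one group for another on this phenyl ring while keeping its place; the nearest evidence is a 1.1-fold lower number from compound 1 to compound 2 (0.03 log units; within the scatter), where changing both the group and where it sits left the number where it was. On that basis no step beyond the scatter is expected in this assay for compound 3, and a 1.0-fold higher number from compound 2 to compound 3 (0.02 log units; within the scatter) is the estimated step. The expected value for compound 3 in this assay is 250 nM, with a range from 120 nM to 520 nM.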

Compound 3, half-maximal inhibitory concentration: 280 nM
Compound 3: middle estimate off by 1.1-fold (0.05 log units), on the low side, within the range that was stated.
By their numbers in this assay, from the lowest: compounds 2, 1 and 3 (each within the scatter of the next).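

Holding the substituent's place on the phenyl ring, the change from 2-cyanophenyl to 2-bromophenyl gives the first direct exchange of one group for another in this assay (a 1.2-fold higher number from compound 2 to compound 3 (0.07 log units; within the scatter)). At this place, a nitrile of two heavy atoms with a triple bond and a hydrogen-bond acceptor gives way to a single bromine with no hydrogen-bond acceptor, and the step stays within the scatter. The comparison with the 3-chlorophenyl compound, where both the group and its place change (a 1.1-fold higher number from compound 1 to compound 3 (0.03 log units; within the scatter)), is also within the scatter, so compounds 1, 2 and 3 stand level in this assay. No accompanying observation bears on why these numbers stay level.

The three compounds shown carry only chloro, cyano and bromo on this phenyl ring, so it remains open whether an amine or a carboxylic acid there would also leave the number level. Also open, going by these compounds, is whether any such group would behave in the same way at the place held by the chloro group of compound 1, and how the unsubstituted phenyl ring compares.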